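The source may report more compounds than this note shows. Statements on the series, on what has been measured and on what is new or still open speak of the compounds shown alone.

Of the compounds shown here, two have so far been measured in a functional assay on the whole organism for inhibition, with Rattus norvegicus as the target, with a stated time of 30 min, at a dose of 1 mg/kg by the intravenous route; on this read-out higher numbers stand for more inhibition at the one dose given (going by the name of the read-out) and lower numbers for less inhibition. Compound 1 `O=C(O)CCCCCNC(=O)c1cc(=O)c2ccccc2o1` carries an acid-bearing chain on the amide side of the shared core, and in this assay compound 1 gives 0%. Compound 2 `Cc1c(C(=O)Nc2nnn[nH]2)oc2ccccc2c1=O` differs from it both on the core and at the amide end, and in this assay compound 2 gives 70%. Compound 1 therefore stands lowest of the two numbers, and the gap to compound 2 lies beyond the scatter.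

Compound 3 `O=C(O)CCNC(=O)c1cc(=O)c2ccccc2o1` has not yet been measured. It differs from compound 1 in a single place: carboxy in place of 3-carboxypropyl on a saturated chain carbon, two bonds along the chain from an amide-type nitrogen. Among the compounds with values here, no pair of measured compounds shows what such a shortening of the chain does in this assay, so the direction of the step is not known from the data. Because compound 1 sits at 0%, the expected step of a number 10 percentage points higher from compound 1 to compound 3 (within the scatter) is small and may not reach beyond the scatter. Compound 3 is therefore expected to give about 10% in this assay, in a range estimated from 0% to 35%.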

Compound 3, a percentage reported as inhibition, in the whole organism at one dose (the size of the read-out at that dose, not a potency): 0%
Compound 3: the middle estimate sits 10 percentage points above what was measured; low and high end bracket the measured number.
By their numbers in this assay, from the lowest: compounds 1 and 3 (each within the scatter of the next); then compound 2.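

Putting carboxy in place of 3-carboxypropyl, on a saturated chain carbon, two bonds along the chain from an amide-type nitrogen, gives no change at the digits printed from compound 1 to compound 3 (within the scatter) in this assay. Within the data shown here, this is the first step measured at this position, and it shows that, for this pair of acid-bearing chains on the shared core, chain length does not bring out any inhibition at the one dose tested: compound 1 gives 0% and compound 3 gives 0%. No measurement of any other kind accompanies these two compounds, so the data offer no explanation for this result.

With both values at nil, this pair cannot tell whether either chain is better suited than the other, only that neither shows inhibition in this assay under these conditions. Still open, from the compounds shown here alone, is whether a different group at this place would read differently, such as a longer chain than 3-carboxypropyl, or an amine in place of the carboxylic acid at the chain end.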